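The source may report more compounds than this note shows. Statements on the series, on what has been measured and on what is new or still open speak of the compounds shown alone.

Compound 1, with the structure `C[C@H](NC(=O)CN(c1nc(Cl)nc2[nH]cnc12)C1CC1)C(=O)OCc1ccccc1`, was tested in a functional assay on the whole organism (Tail, strain ICR) with Mus musculus as the target, in the tail flick test, with a stated time of 120 min, at a dose of 25 umol/kg by the oral route (on this read-out higher numbers stand for a stronger effect at the one dose given and lower numbers for a weaker effect), and gave 36.1%. Its only measured companion, compound 2 with the structure `O=C(OCc1ccccc1)[C@@H]1CCCN1C(=O)CN(c1nc(Cl)nc2[nH]cnc12)C1CC1`, gave 38.4% in this assay. The two numbers sit within the usual scatter of each other, so neither compound can be called the stronger of the pair; compound 1 is simply one of two results that read alike. Both share the same core and differ only in the ester-bearing part attached to the amide.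

Compound 3, with the structure `O=C(CN(c1nc(Cl)nc2[nH]cnc12)C1CC1)N[C@@H](CC(=O)OCc1ccccc1)C(=O)OCc1ccccc1`, has not yet been measured. Compared with compound 1 it carries one change: benzyloxycarbonyl in place of hydrogen on a saturated chain carbon, two bonds along the chain from an amide-type nitrogen and a carbonyl carbon. Within the data shown here, since no measured step of this kind is available among the compounds at hand, there is nothing that would point toward a clear gain or a clear loss, and the two measured compounds already show that changes in this part of the molecule leave the read-out about where it was. The step expected from compound 1 to compound 3 is therefore a number 1.1 percentage points lower from compound 1 to compound 3 (within the scatter), which is within the usual scatter. Compound 3 is estimated to give 35% in this assay, with a likely range from 20% to 50%.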

Compound 3, a percentage reported as activity, at one dose (the size of the read-out at that dose, not a potency): 12.1%
Estimate against measurement, compound 3: 22.9 percentage points above, outside the stated range (below it).
By their numbers in this assay, from the lowest: compound 3; then compounds 1 and 2 (each within the scatter of the next).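

At this position, the chain carbon of compound 1 that carries a methyl group is not indifferent to what is attached to it in this assay: benzyloxycarbonyl in place of hydrogen on that carbon, which turns methyl into (benzyloxycarbonyl)methyl, gives a number 24 percentage points lower from compound 1 to compound 3 (beyond the scatter). Among these compounds, the earlier compounds offered no step between two measured structures that differ in one place, so this is the first evidence that a change here can move the read-out beyond the usual scatter, and the move is downward, toward a weaker effect at the one dose given. The data show only the size and direction of this drop and contain no separate measurement that could explain it.

From the compounds shown here alone, it remains open whether the weaker effect goes with the whole benzyloxycarbonyl group or only with part of it, a question that a carboxylic acid or a methyl ester on the same carbon would help to settle. Going by these compounds, it is also open whether a longer chain between this carbon and the ester would deepen the drop or reverse it.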